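Trading a Nitrobenzyl Arm for a Trifluoromethylphenyl Ring

This account rests on a few compounds, and the source may have more. Where it says the series, first, only, none or still open, it means among the compounds named here.

Of the compounds shown here, three sharing one core have been tested in a functional assay on BJAB cells (Homo sapiens) for antiproliferative activity, with a stated time of 4 days; on this read-out higher numbers stand for an effect only at larger amounts of compound and lower numbers for an effect already at smaller amounts. Compound 1 `Cc1nn(-c2nc(-c3ccc(Cl)c(Cl)c3)c(SC(C)C)s2)c(C(=O)O)c1-c1ccccc1` gives 3000 nM. Compound 2 `Cc1nn(-c2nc(-c3ccc(Cl)c(Cl)c3)c(SC(C)C)s2)c(C(=O)O)c1Cc1ccccc1[N+](=O)[O-]` gives 20000 nM, the highest of the three numbers. Compound 3 `COc1cc(C#N)cc(-c2c(C)nn(-c3nc(-c4ccc(Cl)c(Cl)c4)c(SC(C)C)s3)c2C(=O)O)c1` gives 5200 nM.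

Compound 4 `Cc1nn(-c2nc(-c3ccc(Cl)c(Cl)c3)c(SC(C)C)s2)c(C(=O)O)c1-c1ccccc1C(F)(F)F` is not yet measured. It differs from compound 2 in one place: 2-(trifluoromethyl)phenyl in place of 2-nitrobenzyl on an aromatic carbon.

Two measured steps speak to this change. Going from compound 1 to compound 2, phenyl was replaced by 2-nitrobenzyl and the number rose, a 6.7-fold higher number from compound 1 to compound 2 (0.82 log units; beyond the scatter). Going from compound 2 to compound 3, 2-nitrobenzyl gave way to 3-cyano-5-methoxyphenyl and the number fell, a 3.8-fold lower number from compound 2 to compound 3 (0.59 log units; beyond the scatter). Both times 2-nitrobenzyl sat at the weaker end. Since compound 4 again removes 2-nitrobenzyl, a lower number is expected, on a scale between those two steps, so that the estimated step of a 5.0-fold lower number from compound 2 to compound 4 (0.70 log units; beyond the scatter) lies beyond the scatter. Compound 4 is therefore expected to give 4000 nM in this assay, with a likely range from 1500 nM to 12000 nM.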

Compound 4, half-maximal effective concentration: 5200 nM
Compound 4: the middle estimate sits 1.3-fold (0.11 log units) below what was measured; the measured number falls inside the stated range.
By their numbers in this assay, from the lowest: compounds 1, 3 and 4 (each within the scatter of the next); then compound 2.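

Replacing 2-nitrobenzyl with 2-(trifluoromethyl)phenyl gives a 3.8-fold lower number from compound 2 to compound 4 (0.59 log units; beyond the scatter) in this assay, so compound 2 now stands apart, beyond the scatter, from all three other compounds at this position. Trifluoromethyl on the phenyl ring gives a 1.7-fold higher number from compound 1 to compound 4 (0.24 log units; within the scatter), and exchanging the substituted phenyl ring of compound 3 for this one gives no change at the digits printed from compound 3 to compound 4 (within the scatter), so neither step moves the number beyond the scatter. Nothing measured here accounts for these results.

The compounds shown leave open whether the gap belongs to the extra carbon of 2-nitrobenzyl or to its nitro group, as both change together in every step from compound 2. An unsubstituted benzyl group could separate the two, while an amine on the phenyl ring would test a substituent of another kind.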